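Furan-2-yl in Place of Cyano in a Cytotoxicity Series

The source may hold more compounds than are shown below. What is called first, only, known or untested is meant among the compounds shown, and "the series" means these compounds.

Of the compounds shown here, three sharing one core have been measured in an ADME assay on PC-3 cells (Homo sapiens) for cytotoxicity, read by WST assay, tested at 100 uM; a higher number here means more inhibition at the concentration tested (going by the name of the read-out), a lower number less inhibition. Compound 1 `Cc1cccc(C(=O)N2CCCC(C(=O)Nc3ccc(Cl)cc3)C2)c1` gives 0%; compound 2 `CS(=O)(=O)c1cccc(C(=O)N2CCCC(C(=O)Nc3ccc(Cl)cc3)C2)c1` gives 2%; compound 3 `N#Cc1cccc(C(=O)N2CCCC(C(=O)Nc3ccc(Cl)cc3)C2)c1` gives 0%. The steps among them are all within the scatter: a number 2 percentage points higher from compound 1 to compound 2 (within the scatter), no change at the digits printed from compound 1 to compound 3 (within the scatter) and a number 2 percentage points lower from compound 2 to compound 3 (within the scatter). Compound 3 thus stands level with compound 1 at the digits printed; its nearest neighbour is compound 1 and its furthest is compound 2, both within the scatter.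

Compound 4 `O=C(Nc1ccc(Cl)cc1)C1CCCN(C(=O)c2cccc(-c3ccco3)c2)C1` has not yet been measured. It differs from compound 3 in one place: furan-2-yl in place of cyano on an aromatic carbon. Among the compounds with values here, none of the measured steps exchanges a group of this kind; each of them swaps one group for another on an aromatic carbon, and each stays within the scatter. On that basis no step beyond the scatter is expected in this assay from compound 3 to compound 4, and the expected step is a number 3 percentage points higher from compound 3 to compound 4 (within the scatter). Compound 4 is accordingly estimated at 3%, within a range from 0% to 15%.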

Compound 4, a percentage reported as inhibition, at one concentration (the size of the read-out at that concentration, not a potency): 0%
The estimate for compound 4 lay 3 percentage points above the measured number; measured number inside the range.
By their numbers in this assay, from the lowest: compounds 1, 3, 4 and 2 (each within the scatter of the next).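

Furan-2-yl is the first group in this series to bring a five-membered aromatic ring onto this aromatic carbon, meta to a large group, and with its 5 heavy atoms it is also the largest of the groups compared by that count against cyano. In this assay, the exchange gives no change at the digits printed from compound 3 to compound 4 (within the scatter), and the comparisons with the other two groups give no change at the digits printed from compound 1 to compound 4 (within the scatter) and a number 2 percentage points lower from compound 2 to compound 4 (within the scatter). All four compounds therefore lie within the scatter of one another, so an added aromatic ring at this place does not separate compound 4 from the smaller groups.

The compounds shown leave open whether an amine or a carboxylic acid on this aromatic carbon would produce a step beyond the scatter. No evidence accompanies these compounds to say why the numbers remain so close.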